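From amino to methoxy on a shared core

The compounds below may be only part of what the source reports. "The series", "measured", "known", "first", "only" and "open" are said of these compounds alone.

Among the measured compounds shown here, in a functional assay on HeLa cells (Homo sapiens) for inhibition, read by thymidine incorporation, with a stated time of 3 h (on this read-out higher numbers stand for weaker inhibition and lower numbers for stronger inhibition), compound 1 (`CCCCc1ccc(Nc2nc(N)c3[nH]cnc3n2)cc1`) gives 23000 nM as its result, the lowest of the two numbers so far. In this assay compound 2 (`CCCCc1ccc(Nc2nc3ncnc-3c[nH]2)cc1`) gives 47000 nM as its result, higher than that of compound 1 by more than the usual scatter. Compound 3 (`CCCCc1ccc(Nc2nc(OC)c3[nH]cnc3n2)cc1`) keeps the core of compound 1 and carries methoxy in place of amino on an aromatic carbon. For the measured compounds named here, no measured pair shows this change, so there is no direct guide to its size. In this assay a small move toward weaker inhibition is expected, quite possibly none beyond the scatter. The expected step is a 1.5-fold higher number from compound 1 to compound 3 (0.18 log units; within the scatter) on this estimate. For compound 3 the estimate is 35000 nM as the expected value, with an expected range from 12000 nM to 90000 nM around it.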

Compound 3, half-maximal inhibitory concentration: 30000 nM
The estimate for compound 3 lay 1.2-fold (0.07 log units) above the measured number; low and high end bracket the measured number.
By their numbers in this assay, from the lowest: compounds 1, 3 and 2 (each within the scatter of the next, the first and the last beyond it).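

In this assay, placing methoxy in place of amino on an aromatic carbon, next to the ring nitrogen, gives a 1.3-fold higher number from compound 1 to compound 3 (0.12 log units; within the scatter) and so leaves the result within the scatter. At this position of the shared core, then, compound 1 and compound 3 cannot be told apart, even though amino carries 1 hydrogen-bond donor and methoxy carries 0 hydrogen-bond donors, a comparison that compounds 1 and 2 alone could not offer. Nothing available explains why the exchange leaves the number within the scatter.

The compounds shown leave open whether a hydroxyl, an ethoxy or a dimethylamino group on this carbon would give a step beyond the scatter. They also leave open whether methoxy and amino would stay as close if a longer chain replaced the butyl group.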